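The source may report more compounds than this note shows. Statements on the series, on what has been measured and on what is new or still open speak of the compounds shown alone.

Of the compounds shown here, two sharing one core have been measured in a functional assay on CHO cells for antagonist activity at sphingosine 1-phosphate receptor 2 (Homo sapiens), read by calcium flux; on this read-out higher numbers stand for weaker inhibition and lower numbers for stronger inhibition. Compound 1 `CC(C(=O)O)c1nn(Cc2cn3cc(OCC4CC4)c(Cl)cc3n2)c2ccccc2c1=O` gives 6 nM. Compound 2 `CC(C)(C(=O)O)c1nn(Cc2cn3cc(OCC4CC4)c(Cl)cc3n2)c2ccccc2c1=O` gives 7.7 nM. Among the measured compounds shown here, the one step between them, a 1.3-fold higher number from compound 1 to compound 2 (0.11 log units; within the scatter), consists of a methyl in place of hydrogen on a saturated chain carbon bound to an aromatic carbon, a carbonyl carbon and a saturated chain carbon. For the measured compounds named here, on these two numbers compound 2 stands highest of the two, with compound 1 as its only neighbour, and the gap between them lies within the scatter.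

Compound 3 `C[C@H](C(=O)O)c1nn(Cc2cn3cc(OCC4CC4)c(Cl)cc3n2)c2ccccc2c1=O` has not yet been measured in this assay. It differs from compound 2 by 1-carboxyethyl in place of 1-carboxy-1-methylethyl on an aromatic carbon. Compound 3 thus carries the same 1-carboxyethyl group as compound 1, but with a defined stereocentre, whereas compound 1 has this group without defined stereochemistry. Going by the values given here, the only step that bears on this change is a 1.3-fold higher number from compound 1 to compound 2 (0.11 log units; within the scatter), which runs in the opposite direction and lies within the scatter. Reversing that step, compound 3 is expected to show a number close to that of compound 1, and the expected step is a 1.5-fold lower number from compound 2 to compound 3 (0.19 log units; within the scatter), which lies within the scatter. For compound 3 the estimate in this assay is 5 nM, expected to fall between 2 nM and 20 nM.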

Compound 3, half-maximal inhibitory concentration: 3.2 nM
Compound 3: middle estimate off by 1.6-fold (0.19 log units), on the high side, within the range that was stated.
By their numbers in this assay, from the lowest: compounds 3, 1 and 2 (each within the scatter of the next, the first and the last beyond it).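

In this assay, among the compounds shown here, going from 1-carboxy-1-methylethyl to 1-carboxyethyl on this aromatic carbon gives a 2.4-fold lower number from compound 2 to compound 3 (0.38 log units; beyond the scatter), the first step at this position to clear the usual scatter, though only modestly; this step removes a methyl and also brings in a defined stereocentre. The second new step, a 1.9-fold lower number from compound 1 to compound 3 (0.27 log units; within the scatter), does not clear the scatter, so drawing the S configuration has not been shown to change the reading. Compound 1 and compound 3 have the same atoms and bonds, and only one thing separates them: the fact that one of compounds 1 and 3 is drawn with a defined configuration and the other without, at the place where they differ.

The compounds shown leave open how the R form of the 1-carboxyethyl group would read, and so whether the configuration at this carbon matters at all in this assay. They also leave open how the number would move with a longer chain on this carbon, such as 1-carboxypropyl, or with a primary amide or a tetrazole in place of the carboxylic acid.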